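The source may report more compounds than this note shows. Statements on the series, on what has been measured and on what is new or still open speak of the compounds shown alone.

Series in a functional assay on PC-3 cells (Homo sapiens) for inhibition, read by sulforhodamine B assay, with a stated time of 48 h, tested at 50 uM; on this read-out higher numbers stand for more inhibition of growth at the one concentration tested and lower numbers for less inhibition of growth:

- Compound 1 `COc1cc(/C=C/C(=O)/C=C/c2cccc3ccccc23)ccc1OCc1cn(CCOc2cc(=O)oc3ccccc23)nn1`: 20%
- Compound 2 `COc1cc(/C=C/C(=O)/C=C/c2cccc3ccccc23)ccc1OCc1cn(CCCOc2cc(=O)oc3ccccc23)nn1`: 8%
- Compound 3 `COc1ccc(/C=C/C(=O)/C=C/c2ccc(OCc3cn(CCCCCOc4cc(=O)oc5ccccc45)nn3)c(OC)c2)cc1OC`: "not active" (no number reported)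

Compound 3 has no single number: its entry reads "not active" (no number reported), so it cannot be placed numerically against compound 1 or compound 2. Compound 4 `COc1cc(/C=C/C(=O)/C=C/c2cccc3ccccc23)ccc1OCc1cn(CCCCCOc2cc(=O)oc3ccccc23)nn1` differs from compound 3 in one place: naphthalen-1-yl in place of 3,4-dimethoxyphenyl on a double-bonded chain carbon bound to a double-bonded chain carbon. The naphthalen-1-yl group also occurs in compound 1, which gives 20%, and in compound 2, which gives 8%. Both of those compounds have a different linking chain from compound 4, so this is weak support. A small upward step in this assay is expected, possibly none beyond the scatter, and another report without a number remains possible. For compound 4 the estimated value is 10%, with an expected range of 0% to 25%.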

Compound 4, percent growth inhibition at one concentration: "not active" (no number reported)
For compound 4 the study gives words and no number; the estimate stays without a comparison.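

In this assay compound 3 reads "not active" (no number reported) and compound 4 reads "not active" (no number reported) and so no step can be read between them. The compounds shown leave open whether 3,4-dimethoxyphenyl and naphthalen-1-yl differ in growth inhibition on this linking chain. No supporting evidence bears on this result.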